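Swapping the Ring on the Chain Carbon: Compound 1 to 4

The source may hold more compounds than are shown below. What is called first, only, known or untested is meant among the compounds shown, and "the series" means these compounds.

Of the compounds shown here, three have been tested in a functional assay on the whole organism (strain NMRI) with Mus musculus as the target, with a stated time of 60 min, at a dose of 10 mg/kg by the intraperitoneal route; on this read-out lower numbers stand for a weaker effect and higher numbers for a stronger effect at the one dose given. Compound 1 `S=c1[nH]nc(Cc2ccc(Cl)cc2Oc2ccccc2Cl)[nH]1` gives 139%. Compound 2 `CCSc1nnc(Cc2ccccc2Oc2ccccc2)[nH]1` gives 142%, and compound 3 `CCCSc1nnc(Cc2ccccc2Oc2ccccc2)[nH]1` gives 139%. Compound 1 stands level with compound 3, and its gap to compound 2 lies within the scatter, so the three numbers cannot be told apart. Among the compounds with values here, the only step between measured neighbours is a number 3 percentage points lower from compound 2 to compound 3 (within the scatter): a methyl in place of hydrogen on a saturated chain carbon, two bonds along the chain from a sulfur, left the read-out where it was.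

Compound 4 `CCOc1nnc(Cc2ccc(Cl)cc2Oc2ccccc2Cl)[nH]1` has not yet been measured. It differs from compound 1 in one place: a group of 8 heavy atoms (4 carbon, 3 nitrogen, 1 oxygen; one five-membered aromatic ring with 3 hetero atoms) in place of a group of 6 heavy atoms (2 carbon, 3 nitrogen, 1 sulfur; one five-membered aromatic ring with 3 hetero atoms), on a saturated chain carbon bound to an aromatic carbon. Within the data shown here, no measured step exchanges a sulfur-bearing ring for an oxygen-bearing one, so nothing bears on it directly; the one measured step only shows that a small change near that ring stayed within the scatter. Compound 4 is therefore expected at 138%, within 115% to 160%. The estimated step, a number 1 percentage points lower from compound 1 to compound 4 (within the scatter), is expected to be none beyond the scatter.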

Compound 4, a percentage reported as activity, at one dose (the size of the read-out at that dose, not a potency): 122%
Beside the measured number, compound 4's estimate is 16 percentage points above it, within the range that was stated.
By their numbers in this assay, from the lowest: compound 4; then compounds 1, 3 and 2 (each within the scatter of the next).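

In this assay, placing the group of 8 heavy atoms with its oxygen on a saturated chain carbon bound to an aromatic carbon, in place of the group of 6 heavy atoms with its sulfur, gives a number 17 percentage points lower from compound 1 to compound 4 (beyond the scatter). This is the only step shown that lies beyond the scatter, so the read-out does respond to a change at this position, though the size of the step is modest. Nothing measured here explains the drop.

The exchange alters several things at once, including the sulfur, the oxygen, the added carbons and the double bond outside the aromatic ring, so the compounds shown cannot say which of these matters. As far as these compounds go, how an amine or a carboxylic acid would fare in this place also remains open.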